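The source may hold more compounds than are shown below. What is called first, only, known or untested is meant among the compounds shown, and "the series" means these compounds.

Of the compounds shown here, two with a shared core have been measured in a functional assay on SW480 cells (Homo sapiens) for antiproliferative activity, read by MTT assay, with a stated time of 48 h; on this read-out higher numbers stand for weaker inhibition and lower numbers for stronger inhibition. Compound 1 (`CC(=O)O[C@@H]1/C=C/[C@@](C)(CCC=C(C)C)C/C=C(/CO)C(=O)/C=C/[C@@]1(C)O`) gives 4900 nM, and compound 2 (`CCCC(=O)O[C@@H]1/C=C/[C@@](C)(CCC=C(C)C)C/C=C(/CO)C(=O)/C=C/[C@@]1(C)O`) gives 2510 nM. These two numbers lie within the scatter of each other, so compound 2 cannot be ranked against compound 1.

The unmeasured compound 3 (`CC(C)=CCC[C@]1(C)/C=C/[C@@H](OC(=O)c2ccccc2)[C@](C)(O)/C=C/C(=O)/C(CO)=C\C1`) differs from compound 2 by phenyl in place of propyl on a carbonyl carbon. The same difference reads as (propylcarbonyl)oxy to benzoyloxy.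

Going by the values given here, only one measured step bears on this change. That step, a 2.0-fold lower number from compound 1 to compound 2 (0.29 log units; within the scatter), stays within the scatter and also alters the group on this carbonyl carbon, but it exchanges only saturated chains. Among the compounds with values here, no measured compound carries an aromatic ring there, so the evidence is thin and the range must stay wide. No step beyond the scatter is therefore expected in this assay, and no direction is firmly indicated. The estimated change is a 1.1-fold lower number from compound 2 to compound 3 (0.06 log units; within the scatter). For compound 3 the expected value is 2200 nM, with an estimated range from 700 nM to 7000 nM.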

Compound 3, half-maximal inhibitory concentration: 10300 nM
The estimate for compound 3 lay 4.7-fold (0.67 log units) below the measured number, and the stated range ends below it.
By their numbers in this assay, from the lowest: compounds 2 and 1 (each within the scatter of the next); then compound 3.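

In this assay the group on this carbonyl carbon proves able to shift the number: a 4.1-fold higher number from compound 2 to compound 3 (0.61 log units; beyond the scatter) and a 2.1-fold higher number from compound 1 to compound 3 (0.32 log units; beyond the scatter) are both beyond the scatter, whereas the exchange between the two saturated chains, methyl and propyl, stayed within it. Phenyl is thus the first group here to set a compound apart from the others, and it does so towards weaker inhibition, which makes compound 3 the weakest of the three, though both steps are modest. Nothing available here accounts for this shift.

The compounds shown leave open whether the loss belongs to the aromatic ring itself or would also come with any larger group on this carbonyl carbon, a question that a cyclohexyl group or a longer chain could address. They also leave open whether a phenyl carrying a further group, such as methoxy or an amine, would stay with compound 3 or return to the level of compound 1 and compound 2.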